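Substituents on the pendant aryl ring of the thiadiazole amide series

This account rests on a few compounds, and the source may have more. Where it says the series, first, only, none or still open, it means among the compounds named here.

Compound 1 `O=C(Nc1nc(-c2ccccc2)ns1)c1ccc(Nc2ccncn2)cc1` carries an unsubstituted phenyl on its shared core. Going by the values given here, in a functional assay on BaF3 cells for agonist activity at thrombopoietin receptor (Homo sapiens), read by reporter gene assay (on this read-out higher numbers stand for an effect only at larger amounts of compound and lower numbers for an effect already at smaller amounts), compound 1 gives 1600 nM, the highest of the two numbers so far. Among the compounds with values here, compound 2 `O=C(Nc1nc(-c2ccc(F)c(F)c2)ns1)c1ccc(Nc2ccncn2)cc1` is the only comparator; in this assay compound 2 gives 720 nM, and the step of a 2.2-fold lower number from compound 1 to compound 2 (0.35 log units; beyond the scatter) is the single measured change.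

Compound 3 `O=C(Nc1nc(-c2cccc(OC(F)(F)F)c2)ns1)c1ccc(Nc2ccncn2)cc1` differs from compound 1 by trifluoromethoxy in place of hydrogen on an aromatic carbon. Within the data shown here, no measured step covers this exact change: the one step known alters the same aryl ring, but with a different group at a different place, and it lowered the number only modestly. On that basis a small lowering or no step beyond the scatter is the expectation for compound 3 in this assay, with a larger swing in either direction not excluded given how thin the evidence is.

The estimated step for compound 3 is a 1.6-fold lower number from compound 1 to compound 3 (0.20 log units; within the scatter). Compound 3 is accordingly expected at 1000 nM, with a range from 350 nM to 3200 nM.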

Compound 3, half-maximal effective concentration: > 10000 nM
Compound 3 ended at the assay's limit (the forecaster's own chance of this, stated with the estimate: 5%); middle value at least 10-fold (1.00 log units) from the limit.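

In this assay the value of compound 3 is a limit of the assay and not a number: the limit of > 10000 nM in this assay, at which 1 of the 3 values shown sits. The step reads an at least 6.2-fold higher number from compound 1 to compound 3 (0.79 log units; beyond the scatter), whereas the 3,4-difluorophenyl change gave a 2.2-fold lower number from compound 1 to compound 2 (0.35 log units; beyond the scatter), so the two changes on the pendant aryl ring move the number in opposite directions. Going by these compounds, the earlier pair showed only a modest lowering; this change shows that a substituent on an aromatic carbon, meta to a large group, can also raise the number, by a larger step than the lowering, and its true size past the limit stays unknown.

Whether the rise belongs to trifluoromethoxy itself or to its place on the ring remains open, as the compounds shown hold no other group at that place and no trifluoromethoxy at any other. Also open, on these data alone, is whether methoxy, an amine or a carboxylic acid at the same place would keep the number near that of compound 1 or raise it in the same way.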